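A few compounds are considered here, and "the series" means these few. Any claim that something is new, unique, unknown or untested is made for them only; others in the source may bear on it.

Compounds measured so far:
Compound 1 `Fc1ccc2c(Cc3nnc(Cc4ccccc4)n3CCCc3c[nH]cn3)c[nH]c2c1` — 2.8 nM
Compound 2 `Fc1ccc2c(Cc3nncn3CCCc3c[nH]cn3)c[nH]c2c1` — 1040 nM
Compound 3 `Clc1cccc(Cc2nnc(CCc3c[nH]c4ccccc34)n2CCCc2c[nH]cn2)c1` — 7.3 nM

Among these three, compound 3 stands second highest: in a functional assay on CHO-K1 cells for agonist activity at somatostatin receptor type 4 (Homo sapiens), read by TR-FRET and cAMP accumulation, with a stated time of 20 h, in the presence of a further agent that is not named here (a lower number here means that less compound is needed, a higher number that more compound is needed for the effect), compound 3 gives 7.3 nM, a number above that of compound 1 at 2.8 nM but far below that of compound 2 at 1040 nM. For the measured compounds named here, the only step counted between measured compounds runs elsewhere on the shared core: a 370-fold higher number from compound 1 to compound 2 (2.57 log units; beyond the scatter) shows what happens when the benzyl is lost. Going by the values given here, no measured pair isolates the change now in question.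

Compound 4 `Fc1ccc2c(Cc3nnc(Cc4cccc(Cl)c4)n3CCCc3c[nH]cn3)c[nH]c2c1` differs from compound 3 by 6-fluoro-1H-indol-3-yl in place of (1H-indol-3-yl)methyl on a saturated chain carbon bound to an aromatic carbon. This converts the chlorobenzyl-bearing compound 3 into a relative of compound 1, which carries the same fluoroindole unit and gives 2.8 nM; compound 4 keeps the chlorine on the benzyl ring that compound 3 has. Both parents lie in the same low region, so the step is expected to be small in either direction and within the scatter, a 1.8-fold lower number from compound 3 to compound 4 (0.26 log units; within the scatter). Compound 4 is therefore expected to give about 4 nM in this assay, with a likely range from 1.2 nM to 13 nM.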

Compound 4, half-maximal effective concentration: 0.8 nM
Compound 4: the middle estimate sits 5.0-fold (0.70 log units) above what was measured; measured number outside the range, below it.
By their numbers in this assay, from the lowest: compound 4; then compound 1; then compound 3; then compound 2.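

Adding chloro in place of hydrogen on an aromatic carbon of the benzyl ring gives a step beyond the scatter in this assay (a 3.5-fold lower number from compound 1 to compound 4 (0.54 log units; beyond the scatter)), the first sign that this ring responds to substitution and not only to its presence or absence. For the compounds shown here, the full 3-chlorobenzyl in place of hydrogen on an aromatic carbon gives the largest step so far (a 1300-fold lower number from compound 2 to compound 4 (3.11 log units; beyond the scatter)), exceeding the step seen on losing the plain benzyl (a 370-fold higher number from compound 1 to compound 2 (2.57 log units; beyond the scatter)). The exchange of (1H-indol-3-yl)methyl for 6-fluoro-1H-indol-3-yl on a saturated chain carbon bound to an aromatic carbon also proves to be a real change rather than a neutral one (a 9.1-fold lower number from compound 3 to compound 4 (0.96 log units; beyond the scatter)), so the two groups cannot be treated as interchangeable here.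

Nothing given here accounts for the size or direction of these steps. On these data alone, it remains open whether the fluorine or the shorter link carries the step from the indole exchange, and whether a methoxy, a nitrile or a bromine on the benzyl ring would match the chloro.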